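A Fluorophenyl Analogue and Its Expected Solubility

The source may hold more compounds than are shown below. What is called first, only, known or untested is meant among the compounds shown, and "the series" means these compounds.

Compound 1 `CNC(=O)c1cc(C(=O)NC2CC2)cn(Cc2ccc(OC)cc2)c1=O` was examined in a physicochemical assay for solubility; a lower number here means a less soluble compound, a higher number a more soluble compound. In that assay compound 1 reached >= 143 ug/mL, which is a limit of the assay rather than a measured number. Two related compounds share the same core. Compound 2 `CCNC(=O)c1cc(C(=O)NC)c(=O)n(Cc2ccccc2)c1` gave >= 144 ug/mL in this assay, again a limit. Compound 3 `CNC(=O)c1cc(C(=O)NC2CCC2)cn(Cc2ccncc2)c1=O` gave >= 118 ug/mL in this assay, also a limit. Every value shown is therefore a limit. Compound 1 sits at the limit of >= 143 ug/mL in this assay, at which 1 of the 3 values shown sits. Compound 2 sits at the limit of >= 144 ug/mL in this assay, at which 1 of the 3 values shown sits. Compound 3 sits at the limit of >= 118 ug/mL in this assay, at which 1 of the 3 values shown sits. No ranking among the three can be read from these numbers.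

Compound 4 `CNC(=O)c1cc(C(=O)NC2CC2)cn(Cc2ccccc2F)c1=O` has not yet been measured in this assay. It differs from compound 1 in one place: 2-fluorophenyl in place of 4-methoxyphenyl on a saturated chain carbon bound to an aromatic nitrogen. Among the measured compounds shown here, no measured pair isolates a comparable change; the size of the step cannot be drawn from the data, and the three limits give no direction either. The author expects the step to be an at least 1.1-fold lower number from compound 1 to compound 4 (0.04 log units; that floor lies within the scatter), essentially none beyond the scatter. For compound 4 the expected solubility in this assay is estimated at 130 ug/mL, within 50 ug/mL to 200 ug/mL, and it may well again be reported only as a limit.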

Compound 4, solubility: >= 145 ug/mL
Compound 4: only a limit was reported; the forecaster's own chance of this, stated with the estimate: 60%; middle value at least 1.1-fold (0.04 log units) away from the limit.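

In this assay compound 4 gave >= 145 ug/mL, which is a limit of the assay. Compound 1 gave >= 143 ug/mL, also a limit. Among the compounds shown here, with only these two limits, no step from compound 1 to compound 4 can be read. The compounds shown leave open the actual solubility of each compound, and whether 2-fluorophenyl in place of 4-methoxyphenyl changes it at all.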